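The source may hold more compounds than are shown below. What is called first, only, known or untested is meant among the compounds shown, and "the series" means these compounds.

Measured compounds:
Compound 1 `CC(C)(N)CC(=O)N[C@@H]1CCc2ccccc2N(Cc2ccc(-c3ccccc3-c3nnn(CC(=O)O)n3)cc2)C1=O` gives 0.2 uM in a functional assay (Pituitary gland cell) with Rattus norvegicus as the target; on this read-out lower numbers stand for an effect already at smaller amounts and higher numbers for an effect only at larger amounts of compound.
Compound 2 `COC(=O)c1ccccc1-c1ccc(CN2C(=O)[C@H](NC(=O)CC(C)(C)N)CCc3ccccc32)cc1` gives 2 uM in this assay.

Of the two measured values, compound 1 has the lowest number; the nearest is compound 2, and the step of a 10-fold higher number from compound 1 to compound 2 (1.00 log units; beyond the scatter) shows how far apart they lie. Within the data shown here, the one structural change recorded so far replaces the whole tetrazole-bearing group with a methoxycarbonyl group, which is a different kind of change from the one considered now.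

Compound 3 `CC(C)(N)CC(=O)N[C@@H]1CCc2ccccc2N(Cc2ccc(-c3ccccc3-c3nnnn3CC(=O)O)cc2)C1=O` keeps every atom of compound 1 but joins them differently: 1-(carboxymethyl)-1H-tetrazol-5-yl in place of 2-(carboxymethyl)-2H-tetrazol-5-yl on an aromatic carbon. The carboxymethyl chain therefore simply moves from one nitrogen of the tetrazole ring to another, while the acid, the ring and the rest of the shared core are unchanged. Among the measured compounds shown here, no measured step speaks directly to such a shift of the chain within the ring, so the expectation rests on the fact that the group itself stays the same in size and composition. Compound 3 is therefore expected to stay close to compound 1, with the estimated step of a 2.0-fold higher number from compound 1 to compound 3 (0.30 log units; within the scatter) not expected to go beyond the scatter. The estimate for compound 3 is 0.4 uM, within a range from 0.1 uM to 2 uM.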

Compound 3, concentration for half-maximal effect: 1 uM
Compound 3: the middle estimate sits 2.5-fold (0.40 log units) below what was measured; the range from low to high includes it.
By their numbers in this assay, from the lowest: compound 1; then compounds 3 and 2 (each within the scatter of the next).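

Moving the carboxymethyl chain from one tetrazole nitrogen to another, with the same atoms and the same counts of donors and acceptors, still registers in this assay, as the record shows a 5.0-fold higher number from compound 1 to compound 3 (0.70 log units; beyond the scatter). At this place, on an aromatic carbon ortho to a large group, the arrangement of the tetrazole group therefore matters and not only its composition, and the advantage that the 2-(carboxymethyl)-2H-tetrazol-5-yl group showed over methoxycarbonyl does not extend to its isomer, since the comparison with the ester gives a 2.0-fold lower number from compound 2 to compound 3 (0.30 log units; within the scatter) and stays within the scatter. The data at hand offer no measurement that would explain why the two isomers differ.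

The compounds shown leave open how a plain carboxylic acid at this place, or a tetrazole carrying no chain on its nitrogen, would compare with compound 1 in this assay. Going by these compounds, it also remains open whether a longer chain ending in a carboxylic acid, such as carboxyethyl, would show the same difference between the two ring nitrogens.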